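Will a difluorobenzyl group restore activity?

The source may report more compounds than this note shows. Statements on the series, on what has been measured and on what is new or still open speak of the compounds shown alone.

Compound 1 `Cc1ccc(CNc2ncnc3c2ncn3[C@@H]2O[C@H](CO)[C@@H](O)[C@H]2O)cc1`: > 166000 nM (a limit)
Compound 2 `OC[C@H]1O[C@@H](n2cnc3c(NCc4ccc(Cl)c(Cl)c4)ncnc32)[C@H](O)[C@@H]1O`: 3800 nM
Compound 3 `COc1cc(CNc2ncnc3c2ncn3[C@@H]2O[C@H](CO)[C@@H](O)[C@H]2O)cc(OC)c1`: > 166000 nM (a limit)

All three were tested in a functional assay on CCRF-CEM cells (Homo sapiens) for antiproliferative activity, with a stated time of 72 h; a lower number here means a stronger inhibitor, a higher number a weaker inhibitor. Compound 3 has no exact number, only the limit > 166000 nM. Going by the values given here, this is a common result so far: the limit of > 166000 nM in this assay, at which 2 of the 3 values shown sit. The next compound, compound 4 `OC[C@H]1O[C@@H](n2cnc3c(NCc4ccc(F)cc4F)ncnc32)[C@H](O)[C@@H]1O`, keeps the shared core but swaps the ring group on the saturated chain carbon bound to a nitrogen on an aromatic ring: 2,4-difluorophenyl in place of 3,5-dimethoxyphenyl on a saturated chain carbon bound to a nitrogen on an aromatic ring.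

Three measured steps changed this same group. One gives no usable size: a step that the two limits leave unreadable from compound 1 to compound 3. The other two are large: an at least 43-fold lower number from compound 1 to compound 2 (1.64 log units; beyond the scatter) and an at least 43-fold higher number from compound 2 to compound 3 (1.64 log units; beyond the scatter). Among the compounds with values here, both involve the 3,4-dichlorophenyl of compound 2, the only compound with a measured number. The 2,4-difluorophenyl also carries halogen atoms, so a lower number is expected in this assay, though compound 4 may still only reach the limit. The expected step is an at least 11-fold lower number from compound 3 to compound 4 (1.04 log units; beyond the scatter). For compound 4, the estimated value is 15000 nM, with an expected range from 1500 nM to 166000 nM.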

Compound 4, half-maximal inhibitory concentration: 7100 nM
Compound 4: the middle estimate sits 2.1-fold (0.32 log units) above what was measured; the range from low to high includes it.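

In this assay, the 2,4-difluorophenyl group gives a clear gain over the 3,5-dimethoxyphenyl group, with an at least 23-fold lower number from compound 3 to compound 4 (1.36 log units; beyond the scatter), and a similar gain over the 4-methylphenyl group, with an at least 23-fold lower number from compound 1 to compound 4 (1.36 log units; beyond the scatter). Compared with the 3,4-dichlorophenyl group, the change gives a 1.9-fold higher number from compound 2 to compound 4 (0.27 log units; within the scatter), so these two rings cannot be told apart in this assay. Both compounds with a halogen-bearing ring now have a measured number, while the other two remain at a limit of the assay: the limit of > 166000 nM in this assay, at which 2 of the 4 values shown sit.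

The compounds shown leave open whether one halogen atom on the ring, as in a 4-chlorophenyl or 4-fluorophenyl group, would be enough. Also open, from the compounds shown here alone, is how a trifluoromethyl or nitrile group on this ring, or a longer chain leading to it, would read in this assay.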